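The source may report more compounds than this note shows. Statements on the series, on what has been measured and on what is new or still open speak of the compounds shown alone.

Measured compounds in a functional assay on DU-145 cells (Homo sapiens) for cytotoxicity, read by sulforhodamine B assay, with a stated time of 48 h; a higher number here means that more compound is tolerated, a lower number that less compound is tolerated:
Compound 1 `N#Cc1ccc(Nc2nc(Oc3ccnc4ccccc34)nc(N3CCN(c4ccc(F)cc4)CC3)n2)cc1C(F)(F)F`: in this assay compound 1 gives > 100000 nM, which is a limit of the assay and not a number.
Compound 2 `N#Cc1ccc(Nc2nc(Oc3ccnc4ccccc34)nc(N3CCN(c4ccccn4)CC3)n2)cc1C(F)(F)F`: in this assay compound 2 gives > 100000 nM, again a limit and not a number.

Within the data shown here, compound 2 therefore stands only at a limit in this assay, and the one further value shown, that of compound 1, is a limit as well. Among the measured compounds shown here, the single measured step, a step that the two limits leave unreadable from compound 1 to compound 2, is left unreadable by the two limits, so neither its size nor its direction is known. The same holds for (the limit of > 100000 nM in this assay, at which 2 of the 2 values shown sit), which records nothing beyond the limit itself.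

Compound 3 `CC(C)N1CCN(c2nc(Nc3ccc(C#N)c(C(F)(F)F)c3)nc(Oc3ccnc4ccccc34)n2)CC1` differs from compound 2 by isopropyl in place of pyridin-2-yl on an amine nitrogen in a ring. For the measured compounds named here, no measured step bears on this change, since the only step in the set is unreadable. The step that the limit leaves unreadable from compound 2 to compound 3 is expected to be indistinguishable from none beyond the scatter, with a strong chance that the assay again reports only a limit. Compound 3 is estimated at 150000 nM in this assay, within 30000 nM to 600000 nM.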

Compound 3, concentration lethal to 50% of the cells: > 100000 nM
Compound 3: a limit, no number; the forecaster's own chance of this, stated with the estimate: 75%; the middle value is on the limit's open side.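

Compound 3 adds no readable step against compound 1 or compound 2, since all three stand at a limit of the assay and not at a number: the limit of > 100000 nM in this assay, at which 3 of the 3 values shown sit. The compounds shown leave open whether any of the three groups on the amine nitrogen in the ring differs from the others in this assay, and by how much.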